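A few compounds are considered here, and "the series" means these few. Any claim that something is new, unique, unknown or untested is made for them only; others in the source may bear on it.

Working notes on the series.

The shared core appears in three measured compounds. Compound 1 `CC(C)[C@H]1CC[C@@]2(CO2)[C@H]2C(=O)OCC(C(=O)OCc3ccc(-c4ccc([N+](=O)[O-])cc4)o3)=C[C@H]12` carries a furanylmethyl ester bearing a nitro-substituted aryl group; in a functional assay on WM 266-4 cells (Homo sapiens) for inhibition, with a stated time of 72 h (a lower number here means a stronger inhibitor, a higher number a weaker inhibitor), compound 1 gives 3600 nM. Compound 2 `CC(C)[C@H]1CC[C@@](O)(CCl)[C@H]2C(=O)OCC(C(=O)O)=C[C@H]12` has a free acid and an open chlorohydrin in place of the epoxide, and in this assay compound 2 gives 550 nM. Compound 3 `CNC(=O)C1=C[C@@H]2[C@@H](C(C)C)CC[C@@]3(CO3)[C@H]2C(=O)OC1` is the methyl amide; in this assay compound 3 gives 5900 nM.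

On these numbers compound 1 and compound 3 sit within the scatter of each other, so no order between them is read. Going by the values given here, compound 2 gives a number beyond the scatter lower than compound 1; no single-point step connects the pair, so only the two values are noted.

Compound 4 `CC(C)[C@H]1CC[C@@]2(CO2)[C@H]2C(=O)OCC(C(=O)OCc3ccc(-c4ccccc4)o3)=C[C@H]12` is not yet measured. It differs from compound 1 in one place: hydrogen in place of nitro on an aromatic carbon. Among the compounds with values here, no measured pair shows this change, so no size can be taken from data for it. The expectation is a step from compound 1 to compound 4 of no change at the digits printed from compound 1 to compound 4 (within the scatter), not beyond the scatter in either direction. Compound 4 is therefore estimated at 3600 nM in this assay, with a range from 1200 nM to 11000 nM.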

Compound 4, half-maximal inhibitory concentration: 960 nM
Estimate against measurement, compound 4: 3.8-fold (0.57 log units) above, and the stated range ends above it.
By their numbers in this assay, from the lowest: compounds 2 and 4 (each within the scatter of the next); then compounds 1 and 3 (each within the scatter of the next).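

Going by these compounds alone, compound 1 and compound 4 form the first pair that differs in one place, and in this assay the pair reads as a 3.8-fold lower number from compound 1 to compound 4 (0.57 log units; beyond the scatter) and so gives the series its first measured size for a single change. The step shows that the aromatic carbon para to a large group, on the six-membered aromatic ring of carbon only, is not silent in this assay: the change from 4-nitrophenyl to phenyl moves the number beyond the scatter, and the lower number lies with the unsubstituted phenyl. Nothing measured on these compounds bears on why removing nitro has this effect.

The step rests on this one pair, so it does not tell whether the difference belongs to nitro alone or would also appear with another group at this carbon, such as an amine, a methoxy group or a carboxylic acid. It also leaves open whether the same change would give a step of similar size on a core with the open chlorohydrin in place of the epoxide, as in compound 2.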